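The source may hold more compounds than are shown below. What is called first, only, known or untested is meant among the compounds shown, and "the series" means these compounds.

Compound 3 `O=C(CCCCCCCCCCc1ccccc1)CC(=O)N[C@H]1CCOC1=O` is one of three compounds of the same series tested in a functional assay on NCI-H630 cells (Homo sapiens) for cytotoxicity, read by sulforhodamine B assay, with a stated time of 5 days; on this read-out higher numbers stand for weaker inhibition and lower numbers for stronger inhibition. In this assay compound 2 `O=C(CCCCCCCCCCc1ccccc1)N[C@H]1CCOC1=O` gives 70000 nM. For compound 1 `O=C(CCCCCCCCc1ccccc1)N[C@H]1CCOC1=O` the assay reports only a limit, > 100000 nM (the limit of > 100000 nM in this assay, at which 1 of the 3 values shown sits). In this assay compound 3 gives 23000 nM, the lowest of the two numbers available, with compound 2 the nearest at a gap beyond the usual scatter. Compound 4 `O=C(CCCCCCCCc1ccccc1)CC(=O)N[C@H]1CCOC1=O` differs from compound 3 in one place: phenyl in place of phenethyl on a saturated chain carbon, eight bonds along the chain from a carbonyl carbon. Among the measured compounds shown here, the only measured step that bears on this change runs the opposite way, an at least 1.4-fold lower number from compound 1 to compound 2 (0.15 log units; that floor lies within the scatter), and its size is only a floor. Read in reverse, the step to compound 4 is expected to raise the number somewhat in this assay, though how far remains open. Compound 4 is therefore expected to give about 50000 nM in this assay, within a range from 20000 nM to 150000 nM, which is an estimated step of a 2.2-fold higher number from compound 3 to compound 4 (0.34 log units; beyond the scatter).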

Compound 4, half-maximal inhibitory concentration: 11000 nM
Compound 4: middle estimate off by 4.5-fold (0.66 log units), on the high side, and the stated range ends above it.
By their numbers in this assay, from the lowest: compound 4; then compound 3; then compound 2. At a limit, above all of these: compound 1.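

In this assay, phenyl in place of phenethyl on a saturated chain carbon, eight bonds along the chain from a carbonyl carbon, gives a 2.1-fold lower number from compound 3 to compound 4 (0.32 log units; beyond the scatter), so on the core of compound 3 the phenyl end carries the lower number. The earlier pair gave only a floor for this change, and the new step shows that it does not read alike on the two cores: the same change on two cores in this assay, an at least 1.4-fold lower number (0.15 log units; that floor lies within the scatter) from compound 1 to compound 2 and a 2.1-fold higher number (0.32 log units; beyond the scatter) from compound 4 to compound 3, at least 2.9-fold (0.47 log units) apart, beyond the scatter of two such steps Compound 1 remains a limit of the assay, > 100000 nM, so the full size of the step on its core is not known.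

As far as these compounds go, whether a still shorter chain would lower the number further on the core of compound 4, or an amine or a carboxylic acid in place of the phenyl would keep it, stays open. The difference between the cores rests on these four compounds alone, so how far it extends to other chains cannot be said.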